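The source may hold more compounds than are shown below. What is called first, only, known or untested is meant among the compounds shown, and "the series" means these compounds.

Three measured anilides share one core: compound 1 `CCn1c(SCC(=O)Nc2ccc(C(C)=O)cc2)nnc1-c1ccc(OC)cc1`, compound 2 `COc1ccc(-c2nnc(SCC(=O)Nc3ccc(C(C)=O)cc3)n2-c2ccccc2)cc1` and compound 3 `CCn1c(SCC(=O)Nc2ccc(C(C)=O)cc2)nnc1-c1ccccc1`; compound 4 `CC(=O)c1ccc(NC(=O)CSc2nnc(-c3ccccc3)n2-c2ccccc2)cc1` remains to be tested. In a functional assay on the whole organism (strain albino) for inhibition, with Rattus norvegicus as the target, read by paw edema, with stated times of 30 min and 2 h, at a dose of 0.28 mmol/kg by the oral route (on this read-out lower numbers stand for less inhibition and higher numbers for more inhibition at the one dose given (going by the name of the read-out)), compound 1 gives 54%, compound 2 gives 42% and compound 3 gives 53%. The cores of compound 1 and compound 3 differ by hydrogen in place of methoxy on an aromatic carbon, which gave a number 1 percentage points lower from compound 1 to compound 3 (within the scatter), so these two cannot be separated in this assay. The change phenyl in place of ethyl on an aromatic nitrogen gave a number 12 percentage points lower from compound 1 to compound 2 (beyond the scatter). Compound 4 carries the same kind of change on the core of compound 3, (phenyl in place of ethyl on an aromatic nitrogen). The surroundings are not identical: in compound 1 the place is next to the ring atom that bears a 4-methoxyphenyl group (8 heavy atoms), in compound 3 next to the ring atom that bears a phenyl group (6 heavy atoms). Going by the values given here, only one earlier instance exists, so the expectation rests on it alone. The step in this assay is expected to be a number 12 percentage points lower from compound 3 to compound 4 (beyond the scatter), a repeat of a number 12 percentage points lower from compound 1 to compound 2 (beyond the scatter). Compound 4 is thus estimated at 41%, expected to lie between 31% and 51%.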

Compound 4, a percentage reported as inhibition, in the whole organism at one dose (the size of the read-out at that dose, not a potency): 49%
For compound 4 the middle estimate is 8 percentage points below the measured one; measured number inside the range.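

In this assay, going by these compounds alone, phenyl in place of ethyl on the aromatic nitrogen gave a number 4 percentage points lower from compound 3 to compound 4 (within the scatter), and this step cannot be told apart from the earlier one: the same change on two cores in this assay, a number 12 percentage points lower (beyond the scatter) from compound 1 to compound 2 and a number 4 percentage points lower (within the scatter) from compound 3 to compound 4, 8 percentage points apart, within the scatter of two such steps Hydrogen in place of methoxy on the aromatic carbon gave a number 7 percentage points higher from compound 2 to compound 4 (within the scatter), and the two steps for this change also agree: the same change on two cores in this assay, a number 1 percentage points lower (within the scatter) from compound 1 to compound 3 and a number 7 percentage points higher (within the scatter) from compound 2 to compound 4, 8 percentage points apart, within the scatter of two such steps Each change therefore carries from one core to the other within the scatter, but with only two steps per change this shows no more than the absence of a detectable core dependence, and it does not establish a consistent fall for phenyl in place of ethyl, as only the step on the core of compound 1 lies beyond the scatter.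

The compounds shown hold only ethyl or phenyl on the aromatic nitrogen and only hydrogen or methoxy on the aromatic carbon. From the compounds shown here alone, whether the same agreement holds for a longer chain such as propyl or for a benzyl group on that nitrogen, or for chlorine or an amine in place of the methoxy, stays open.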